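Pyrimidin-4-yl in Place of Phenyl on the Amide Nitrogen

A few compounds are considered here, and "the series" means these few. Any claim that something is new, unique, unknown or untested is made for them only; others in the source may bear on it.

Of the compounds shown here, two sharing one core have been measured in a physicochemical assay for lipophilicity, read by HPLC, in phosphate buffer, measured as chromatographic lipophilicity, at pH 7.4; a lower number here means a more polar compound, a higher number a more lipophilic compound. Compound 1 `CCOc1ccc2nc(C(F)(F)F)cc(OCC(=O)Nc3cc(C)cc(C)c3)c2c1` gives 7.55, while compound 2 `COc1ccc2nc(C)cc(OCC(=O)Nc3ccccc3)c2c1` gives 4.28, the lower of the two numbers, with compound 1 standing higher by more than the usual scatter. Compound 3 `COc1ccc2nc(C)cc(OCC(=O)Nc3ccncn3)c2c1` is not yet measured; it differs from compound 2 in one place: pyrimidin-4-yl in place of phenyl on an amide-type nitrogen. Replacing the all-carbon ring with one carrying two hydrogen-bond acceptors is expected to lower the value, so compound 3 is estimated at 3, within a range of 2.3 to 3.7. The expected step of a number 1.28 log units lower from compound 2 to compound 3 (beyond the scatter) should exceed the scatter.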

Compound 3, distribution coefficient: 2.53
Estimate against measurement, compound 3: 0.47 log units above; the measured number falls inside the stated range.
By their numbers in this assay, from the lowest: compound 3; then compound 2; then compound 1.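

Within the data shown here, this is the first change that can be read in one place alone: in this assay, pyrimidin-4-yl in place of phenyl on the amide-type nitrogen gives a number 1.75 log units lower from compound 2 to compound 3 (beyond the scatter) for this pair. The ring size stays the same and neither group carries a net charge, yet swapping ring carbon for ring nitrogen at this position is enough for a large step. Nothing measured here gives the reason for it. Still open, on these data alone, is where a pyridin-3-yl ring on the same nitrogen would fall, and whether a step of this size would recur on the core of compound 1.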